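The compounds below may be only part of what the source reports. "The series", "measured", "known", "first", "only" and "open" are said of these compounds alone.

For the measured compounds named here, compound 2 `COCCOc1ccc(-c2sc(N)c(C(=O)c3ccc(Cl)cc3)c2CC(C)(C)C)cc1` stands lowest of the two numbers so far in an assay on CHO cells for displacement of a labelled ligand from adenosine receptor A3 (Homo sapiens), read by scintillation counting, tested at 10 uM (on this read-out lower numbers stand for less inhibition and higher numbers for more inhibition at the one concentration tested (going by the name of the read-out)), where compound 2 gives 1%. Its nearest neighbour, compound 1 `CC(C)(C)Cc1c(-c2ccc(F)cc2)sc(N)c1C(=O)c1ccc(Cl)cc1`, gives 9% in this assay, and the step of a number 8 percentage points lower from compound 1 to compound 2 (within the scatter), with 2-methoxyethoxy in place of fluoro on an aromatic carbon, lies within the scatter. Compound 3 `CC(C)(C)Cc1c(-c2ccc(OC(F)(F)F)cc2)sc(N)c1C(=O)c1ccc(Cl)cc1` differs from compound 2 by trifluoromethyl in place of 2-methoxyethyl on an oxygen on an aromatic ring. Going by the values given here, only the one measured step bears on this change, and only loosely: it too exchanged the group at this position of the aromatic ring, and it left the number essentially where it was, with both compounds low. Nothing in these two numbers points to a move beyond the scatter in this assay. For compound 3 the expected step is a number 4 percentage points higher from compound 2 to compound 3 (within the scatter). The estimate for compound 3 in this assay is 5%, with a range from 0% to 20%.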

Compound 3, a percentage reported as inhibition, at one concentration (the size of the read-out at that concentration, not a potency): 1%
Beside the measured number, compound 3's estimate is 4 percentage points above it; the measured number falls inside the stated range.
By their numbers in this assay, from the lowest: compounds 2, 3 and 1 (each within the scatter of the next).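

In this assay, trifluoromethyl in place of 2-methoxyethyl on an oxygen on an aromatic ring gives no change at the digits printed from compound 2 to compound 3 (within the scatter) and trifluoromethoxy in place of fluoro on an aromatic carbon gives a number 8 percentage points lower from compound 1 to compound 3 (within the scatter). Three different groups have now stood at this position, two of them joined through oxygen and one a lone fluoro, and all three compounds lie within the scatter of one another, so neither change separates from the others in this assay. Nothing on hand bears on why these numbers stay together.

On these data alone, it remains open whether an amine or a carboxylic acid on this aromatic ring would move the number beyond the scatter. As far as these compounds go, it also remains open whether a change elsewhere on the shared core would do so.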